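Replacing a ring-bearing group on compound 1

The source may report more compounds than this note shows. Statements on the series, on what has been measured and on what is new or still open speak of the compounds shown alone.

Within the data shown here, in a functional assay on HeLa cells (Homo sapiens) for inhibition, read by MTT assay, with a stated time of 48 h (a higher number here means a weaker inhibitor, a lower number a stronger inhibitor), compound 1 `CCOC(=O)C1=C(N/C=N/c2cccnc2Cl)Nc2[nH]nc(C)c2C1c1ccc(N(C)C)cc1` gives 4630 nM, the lowest of the three numbers measured so far. Compound 2 `CCOC(=O)C1=C(NN=C(C(C)=O)C(C)=O)Nc2[nH]nc(C)c2C1c1ccc(N(C)C)cc1` gives 17000 nM, and compound 3 `CCOC(=O)C1=C(N/N=C(\c2ccc([N+](=O)[O-])cc2)N2CCN(c3ccc(F)cc3)CC2)Nc2[nH]nc(C)c2C1c1ccc(N(C)C)cc1` gives 87000 nM. Compound 4 `CCOC(=O)C1=C(N/N=C(/C#N)C(=O)OCC)Nc2[nH]nc(C)c2C1c1ccc(N(C)C)cc1` is still unmeasured. It differs from compound 1 on an amine nitrogen: a group of 9 heavy atoms (5 carbon, 2 nitrogen, 2 oxygen; no ring) in place of a group of 9 heavy atoms (6 carbon, 2 nitrogen, 1 chlorine; one six-membered aromatic ring with 1 hetero atom), on an amine nitrogen. Among the measured compounds shown here, the group entering has no ring, and the same is true of the group that replaces the same ring-bearing group in the one comparable measured step, a 3.7-fold higher number from compound 1 to compound 2 (0.56 log units; beyond the scatter). For the measured compounds named here, that step is modest and is only a single example, but it points upward. A rise of similar size is expected here, an estimated 3.2-fold higher number from compound 1 to compound 4 (0.51 log units; beyond the scatter). For compound 4 the estimated value is 15000 nM, with an expected range of 5000 nM to 50000 nM.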

Compound 4, half-maximal inhibitory concentration: 39200 nM
Beside the measured number, compound 4's estimate is 2.6-fold (0.42 log units) below it, within the range that was stated.
By their numbers in this assay, from the lowest: compound 1; then compound 2; then compound 4; then compound 3.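

Among these compounds, with compound 4, a second ring-free group on this amine nitrogen also raises the number in this assay (an 8.5-fold higher number from compound 1 to compound 4 (0.93 log units; beyond the scatter)), so the rise seen with compound 2 is no longer a lone example. The two ring-free groups also differ from each other (a 2.3-fold higher number from compound 2 to compound 4 (0.36 log units; beyond the scatter)), so the identity of the entering group counts, not just the loss of the ring. Nothing measured here explains either rise. Compound 3 gives (87000 nM) with rings in its group, so losing the ring cannot be the whole story. Going by these compounds, how a plain phenyl ring or a ring-free chain ending in an amine would behave here remains open.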